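A Benzyl-to-Aryl Sulfonyl Swap on a Weak Inhibitor

This account rests on a few compounds, and the source may have more. Where it says the series, first, only, none or still open, it means among the compounds named here.

Three compounds were assessed in a functional assay on K562 cells (Homo sapiens) for inhibition, read by trypan blue exclusion, with a stated time of 72 h; on this read-out higher numbers stand for weaker inhibition and lower numbers for stronger inhibition. Compound 1 `Cn1c(=O)c(S(=O)(=O)Cc2ccc(F)cc2)cc2cnc(Nc3ccc4[nH]ccc4c3)nc21` gives 30000 nM, the highest of the three numbers and therefore the weakest inhibition seen, with both gaps to the others beyond the scatter. Compound 2 `Cn1ccc2cc(Nc3ncc4cc(S(=O)(=O)c5ccc(Cl)cc5Cl)c(=O)n(C)c4n3)ccc21` gives 750 nM in this assay. Compound 3 `CN1CCN(c2ccc(Nc3ncc4cc(S(=O)(=O)c5ccc(F)cc5F)c(=O)n(C)c4n3)cc2)CC1` gives 5000 nM in this assay. Compound 4 `Cn1c(=O)c(S(=O)(=O)c2ccc(F)cc2N)cc2cnc(Nc3ccc4[nH]ccc4c3)nc21` has not yet been measured; it differs from compound 1 in one place, (2-amino-4-fluorophenyl in place of 4-fluorobenzyl on a sulfonyl sulfur). Among the measured compounds shown here, compounds 2 and 3 also carry sulfonyl groups bearing aromatic rings rather than a benzyl group, and both give lower numbers than compound 1, though each also differs elsewhere, so no single step isolates the sulfonyl change. An improvement for compound 4 is nonetheless expected, because compound 2 gives 750 nM with a related arrangement. The estimated step from compound 1 to compound 4 is a 6.0-fold lower number from compound 1 to compound 4 (0.78 log units; beyond the scatter), a decrease beyond the scatter. Compound 4 is expected to give 5000 nM, within 1000 nM to 20000 nM.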

Compound 4, half-maximal inhibitory concentration: 2000 nM
Compound 4: the middle estimate sits 2.5-fold (0.40 log units) above what was measured; the range from low to high includes it.
By their numbers in this assay, from the lowest: compound 2; then compound 4; then compound 3; then compound 1.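

Exchanging 4-fluorobenzyl for 2-amino-4-fluorophenyl on the sulfonyl sulfur gives a 15-fold lower number from compound 1 to compound 4 (1.18 log units; beyond the scatter) in this assay, and the core of compound 1 stays unchanged. Among the compounds shown here, compounds 2 and 3 also carry aromatic rings on the sulfonyl group but differ elsewhere too, so this step is the first to show that the sulfonyl substituent alone can move the number by a large amount. No measurement shown here explains the change.

The exchange removes the benzyl carbon and adds an amine in a single step, so the compounds shown leave open how much of the decrease belongs to each change. On these data alone, whether a plain 4-fluorophenyl group or a 2-methylamino-4-fluorophenyl group on the sulfonyl sulfur would keep the lower number also remains open.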